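Cycloheptyl ureas: aryl variation on the benzyl group

The compounds below may be only part of what the source reports. "The series", "measured", "known", "first", "only" and "open" are said of these compounds alone.

Measured in a functional assay on a cell-free system (plasma) with sterol O-acyltransferase, Soat (Rattus norvegicus) as the target; on this read-out lower numbers stand for an effect already at smaller amounts and higher numbers for an effect only at larger amounts of compound:
compound 1 `O=C(Nc1c(F)cc(F)cc1F)N(Cc1ccc(-c2ccccn2)cc1)C1CCCCCC1`, a limit, > 1 mg/kg
compound 2 `Cc1cc(C)c(NC(=O)N(Cc2ccc(-c3ccccn3)cc2)C2CCCCCC2)c(C)c1`, a limit, > 1 mg/kg
compound 3 `Cc1cc(C)c(NC(=O)N(Cc2cccc(-c3cn[nH]c3)c2)C2CCCCCC2)c(C)c1`, 0.19 mg/kg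

Compound 2 stands at a limit, > 1 mg/kg, in this assay, so only a bound is known for it. Two of the three values sit there (the limit of > 1 mg/kg in this assay, at which 2 of the 3 values shown sit). For the measured compounds named here, compound 3 gives 0.19 mg/kg, but it differs from compound 2 in two places, so no step links them. Going by the values given here, the one measured step, a step that the two limits leave unreadable from compound 1 to compound 2, cannot be read from its two limits. Compound 4 `Cc1cc(C)c(NC(=O)N(Cc2ccc(-n3ccnn3)cc2)C2CCCCCC2)c(C)c1` differs from compound 2 by 1H-1,2,3-triazol-1-yl in place of pyridin-2-yl on an aromatic carbon. Among the compounds with values here, no measured step bears on this change, so the expected size and direction rest on little. Compound 4 is estimated at 0.6 mg/kg, between 0.15 mg/kg and 3 mg/kg. The expected step is an at least 1.6-fold lower number from compound 2 to compound 4 (0.22 log units; that floor lies within the scatter), an estimate only.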

Compound 4, dose for half-maximal effect: > 1 mg/kg
Compound 4 ended at the assay's limit; the forecaster's own chance of this, stated with the estimate: 40%; middle value at least 1.6-fold (0.22 log units) from the limit.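

In this assay, for the compounds shown here, compound 2 and compound 4 both stand at a limit, so no step between them can be read. The compounds shown leave open how far either compound lies from that limit, and whether pyridin-2-yl and 1H-1,2,3-triazol-1-yl differ at all.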